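Swapping Cyclohexyl for Trimethoxyphenyl on a Shared Core

This account rests on a few compounds, and the source may have more. Where it says the series, first, only, none or still open, it means among the compounds named here.

Of the compounds shown here, two built on the same core have been tested in a functional assay on HT-1080 cells (Homo sapiens) for cytotoxicity, read by MTT assay, with a stated time of 72 h; on this read-out higher numbers stand for weaker inhibition and lower numbers for stronger inhibition. Compound 1 `COc1cc(Nc2nc(C(=N)Nc3ccccc3)cc3c(-c4ccccc4)n[nH]c23)cc(OC)c1OC` gives 3900 nM in this assay. Compound 2 `COc1ccc(Cn2nc(-c3ccccc3)c3cc(C(=N)Nc4ccccc4)nc(NC4CCCCC4)c32)cc1` gives 3400 nM in this assay. Compound 2 sits at the same level as compound 1, since the difference between their two numbers lies within the scatter of repeated measurements, so neither can be called more or less potent.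

Compound 3 `COc1ccc(Cn2nc(-c3ccccc3)c3cc(C(=N)Nc4ccccc4)nc(Nc4cc(OC)c(OC)c(OC)c4)c32)cc1` has not yet been measured. It differs from compound 2 in one place: 3,4,5-trimethoxyphenyl in place of cyclohexyl on a nitrogen on an aromatic ring. The same trimethoxyphenyl group is present in compound 1, and compound 1 is no different from compound 2 beyond the scatter, so no step beyond the scatter is expected from compound 2 to compound 3; the estimated step is a 1.0-fold higher number from compound 2 to compound 3 (0.01 log units; within the scatter). Compound 3 is therefore expected to give about 3500 nM in this assay, with a likely range from 1500 nM to 9000 nM.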

Compound 3, half-maximal inhibitory concentration: 11100 nM
Beside the measured number, compound 3's estimate is 3.2-fold (0.50 log units) below it; measured number outside the range, above it.
By their numbers in this assay, from the lowest: compounds 2 and 1 (each within the scatter of the next); then compound 3.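

On this assay the nitrogen on an aromatic ring proves sensitive to what it carries: with the rest of the molecule unchanged, 3,4,5-trimethoxyphenyl in place of cyclohexyl raises the number (a 3.3-fold higher number from compound 2 to compound 3 (0.51 log units; beyond the scatter)), a loss of potency. The second place matters as well, since 4-methoxybenzyl in place of hydrogen on an aromatic nitrogen also raises it (a 2.8-fold higher number from compound 1 to compound 3 (0.45 log units; beyond the scatter)), so compound 3, which carries both groups, is set apart from both neighbours by single changes. Nothing measured here bears on the reason for either step.

The compounds shown leave open whether the rise follows the aromatic ring itself or its methoxy groups, which a plain phenyl on that nitrogen could separate. As far as these compounds go, how a plain benzyl or a methyl on the aromatic nitrogen would compare with 4-methoxybenzyl also remains open.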